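Adding isopropyl to the amide of compound 2

The source may report more compounds than this note shows. Statements on the series, on what has been measured and on what is new or still open speak of the compounds shown alone.

Compound 1 (`CC(C)C(Cc1nnn[nH]1)c1ccc(-c2ccc3cccc(F)c3c2)[nH]c1=O`) and compound 2 (`CC(C)C(CC(N)=O)c1ccc(-c2ccc3cccc(F)c3c2)[nH]c1=O`) share a core and differ in one group. In an ADME assay on microsomes from liver (Homo sapiens) for metabolic stability (a higher number here means that the compound lasts longer, a lower number that the compound disappears faster), compound 1 gives > 3 h as a limit of the assay. Compound 2 gives < 0.0667 h as a limit too, and this is the low end of the two values shown. Going by the values given here, the one measured step, carbamoyl in place of 1H-tetrazol-5-yl, is large at an at least 44-fold lower number from compound 1 to compound 2 (1.65 log units; beyond the scatter) and lies beyond the scatter. Compound 3 (`CC(C)NC(=O)CC(c1ccc(-c2ccc3cccc(F)c3c2)[nH]c1=O)C(C)C`) has isopropyl in place of hydrogen on an amide-type nitrogen and so remains an amide. The measured step replaced the whole group, so it bears only indirectly on this smaller change, and no step beyond the scatter is expected. The expected change is an at least 1.0-fold higher number from compound 2 to compound 3 (0.02 log units; that floor lies within the scatter) with no firm direction. In this assay the expected half-life of compound 3 is 0.07 h within an estimated range of 0.03 h to 0.3 h for now.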

Compound 3, half-life: 0.32 h
Compound 3: the middle estimate sits 4.6-fold (0.66 log units) below what was measured; the whole stated range lies below it.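

On the amide-type nitrogen, isopropyl in place of hydrogen gives an at least 4.7-fold higher number from compound 2 to compound 3 (0.68 log units; beyond the scatter) in this assay. So a change that keeps the amide and alters only what sits on its nitrogen can move the half-life beyond the scatter, which the earlier swap of the whole group could not show. Even so, the amide stays well short of the 1H-tetrazol-5-yl compound, with an at least 9.3-fold lower number from compound 1 to compound 3 (0.97 log units; beyond the scatter), and the gain from compound 2 is only a floor because compound 2 stands at a limit of the assay: the limit of < 0.0667 h in this assay, at which 1 of the 3 values shown sits.

Going by these compounds, the size of the gap to the tetrazole also stays open because compound 1 stands at a limit of the assay: the limit of > 3 h in this assay, at which 1 of the 3 values shown sits. Also open is how a methyl, a longer chain or a cyclopropyl on that nitrogen would compare, and whether a carboxylic acid in place of the amide would behave like the tetrazole.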